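Aryl-pyrrole carboxylic acids: meta substituent swap

The compounds below may be only part of what the source reports. "The series", "measured", "known", "first", "only" and "open" are said of these compounds alone.

Measured compounds in an assay on cells for inhibition of Palmitoleoyl-protein carboxylesterase NOTUM variant C330S (Homo sapiens), read by fluorescence, with a stated time of 40 min; on this read-out lower numbers stand for stronger inhibition and higher numbers for weaker inhibition:
compound 1 `Cc1cc(C(=O)O)c(C)n1-c1ccc(Cl)c(C(F)(F)F)c1` gives 2100 nM
compound 2 `Cc1ccc(-n2c(C)cc(C(=O)O)c2C)cc1` gives 2000 nM
compound 3 `Cc1cc(C(=O)O)c(C)n1-c1cccc(C(F)(F)F)c1` gives 1500 nM

The three numbers sit within the usual scatter of one another, so no order among compound 1, compound 2 and compound 3 can be read from this assay. Among the measured compounds shown here, the one single-point step, a 1.4-fold lower number from compound 1 to compound 3 (0.15 log units; within the scatter), removes a chloro from an aromatic carbon and leaves the number essentially where it was.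

Compound 4 `CCOc1cccc(-n2c(C)cc(C(=O)O)c2C)c1` has not yet been measured. Against compound 3 the change is ethoxy in place of trifluoromethyl on an aromatic carbon, with the new group sitting on an aromatic carbon of a six-membered aromatic ring of carbon only, meta to a large group. For the measured compounds named here, no measured step touches this position with these groups: the only step on record changes a chloro elsewhere on the same ring, and compound 2 carries a methyl on that ring with a number indistinguishable from compound 3. Nothing in the series therefore points to a shift beyond the scatter in this assay, in either direction. The expectation for compound 4 is accordingly a 1.2-fold higher number from compound 3 to compound 4 (0.08 log units; within the scatter), that is, a number close to compound 3. Compound 4 is estimated at 1800 nM in this assay, with a plausible range from 600 nM to 5500 nM.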

Compound 4, half-maximal inhibitory concentration: 640 nM
Estimate against measurement, compound 4: 2.8-fold (0.45 log units) above; the measured number falls inside the stated range.
By their numbers in this assay, from the lowest: compound 4; then compounds 3, 2 and 1 (each within the scatter of the next).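

Among the compounds shown here, putting ethoxy in place of trifluoromethyl on this aromatic carbon gives, in this assay, the only step that lies beyond the scatter (a 2.3-fold lower number from compound 3 to compound 4 (0.37 log units; beyond the scatter)), whereas removing the chloro elsewhere on the same ring stays within it (a 1.4-fold lower number from compound 1 to compound 3 (0.15 log units; within the scatter)). This position, meta to a large group, therefore responds to the group placed on it, though only modestly, which the three earlier numbers could not show. The exchange replaces a group of 4 heavy atoms and no hydrogen-bond acceptor with one of 3 heavy atoms and 1 hydrogen-bond acceptor, and no measurement at hand explains why the number moves.

A single step cannot separate the contribution of the oxygen from that of the ethyl chain, so methoxy, propoxy and a plain ethyl group at this place would each be informative. Also open, going by these compounds, is whether the trend continues with a longer or branched ether such as isopropoxy, or whether an amine or a hydroxy group at this place would give a similar number.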